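The source may report more compounds than this note shows. Statements on the series, on what has been measured and on what is new or still open speak of the compounds shown alone.

In a functional assay on K562 cells (Homo sapiens) for cytotoxicity, read by sulforhodamine B assay, with a stated time of 48 h (on this read-out higher numbers stand for weaker inhibition and lower numbers for stronger inhibition), compound 1, `CCn1cc(-c2nc3ccccc3[nH]2)c(=O)c2cc(F)c(N3CCNCC3)cc21`, gives only a limit of the assay, > 10000 nM. Compound 2, `CCn1cc(-c2nc3ccc([N+](=O)[O-])cc3o2)c(=O)c2cc(F)c(N3CCNCC3)nc21`, gives in this assay likewise only a limit, > 10000 nM. Compound 1 thus stands at the limit of > 10000 nM in this assay, at which 2 of the 2 values shown sit, and there is no number that places it among the others. Compound 3, `CCn1cc(-c2nc3ccc(N)cc3[nH]2)c(=O)c2cc(F)c(N3CCNCC3)cc21`, has not yet been measured in this assay. It differs from compound 1 in one place: amino in place of hydrogen on an aromatic carbon. Among the compounds with values here, no step between two measured compounds is known here, and the limit of compound 2 gives no second point of comparison. The expectation for the step from compound 1 to compound 3 is therefore none beyond the scatter, or at most a modest gain, and the step of an at least 1.2-fold lower number from compound 1 to compound 3 (0.09 log units; that floor lies within the scatter) is what is estimated here. For compound 3 the estimated value in this assay is 8000 nM, with a range from 2500 nM to 25000 nM, and the chance that the assay again reports only a limit and no number is expected to remain considerable.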

Compound 3, half-maximal inhibitory concentration: > 10000 nM
Compound 3 was reported as a limit; the forecaster's own chance of this, stated with the estimate: 60%; at least 1.2-fold (0.09 log units) between middle value and limit.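

In this assay compound 3 gives only a limit, > 10000 nM. Compound 1 also gives only a limit, so no step can be read for amino in place of hydrogen from compound 1 to compound 3: the limit of > 10000 nM in this assay, at which 3 of the 3 values shown sit.

The compounds shown leave open what number any of them would reach in this assay, and whether amino changes it at all.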